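This account rests on a few compounds, and the source may have more. Where it says the series, first, only, none or still open, it means among the compounds named here.

Series notes on the shared core of compound 1 `O=C(OC1CCC(CN2CCN(c3cc(=O)c4cc(C(F)(F)F)cc([N+](=O)[O-])c4s3)CC2)CC1)C1CCCCC1`. In an ADME assay on Vero cells (Chlorocebus sabaeus) for cytotoxicity, read by MTT assay, with a stated time of 48 h (on this read-out lower numbers stand for stronger inhibition and higher numbers for weaker inhibition), compound 1 gives > 64 ug/mL, which is a limit of the assay and not a number. Compound 2 `O=c1cc(N2CCN(CC3CCC(OS(=O)(=O)c4ccccc4)CC3)CC2)sc2c([N+](=O)[O-])cc(C(F)(F)F)cc12` carries phenylsulfonyl in place of cyclohexylcarbonyl on an oxygen on a saturated carbon; in this assay compound 2 gives > 64 ug/mL, again a limit. Compound 3 `CS(=O)(=O)OC1CCC(CN2CCN(c3cc(=O)c4cc(C(F)(F)F)cc([N+](=O)[O-])c4s3)CC2)CC1` carries methylsulfonyl in place of cyclohexylcarbonyl on an oxygen on a saturated carbon; in this assay compound 3 gives > 64 ug/mL, also a limit. Hence the steps a step that the two limits leave unreadable from compound 1 to compound 2, a step that the two limits leave unreadable from compound 1 to compound 3 and a step that the two limits leave unreadable from compound 2 to compound 3: every measured step sits at the limit of > 64 ug/mL in this assay, at which 3 of the 3 values shown sit.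

Compound 4 `O=C(NC1CCC(CN2CCN(c3cc(=O)c4cc(C(F)(F)F)cc([N+](=O)[O-])c4s3)CC2)CC1)c1ccccc1` differs from compound 1 as follows: benzamido in place of (cyclohexylcarbonyl)oxy on a saturated ring carbon. For the measured compounds named here, no measured step exchanges the oxygen for a nitrogen or places benzamido; the three measured steps show only that exchanging cyclohexylcarbonyl, phenylsulfonyl and methylsulfonyl on that oxygen leaves every value at the limit. In this assay the step that the limit leaves unreadable from compound 1 to compound 4 is therefore expected to be no step beyond the scatter, with the value again most likely reported as a limit. Compound 4 is estimated at 90 ug/mL, range 45 ug/mL to 180 ug/mL.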

Compound 4, half-maximal inhibitory concentration: 44.3 ug/mL
Compound 4: middle estimate off by 2.0-fold (0.31 log units), on the high side; measured number outside the range, below it.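

In this assay, compound 4 is the only compound shown that gives a number, not a limit, so this saturated ring carbon is the first place in the series where a change yields a readable value. Benzamido in place of the oxygen-linked groups gives an at least 1.4-fold lower number from compound 1 to compound 4 (0.15 log units; that floor lies within the scatter), an at least 1.4-fold lower number from compound 3 to compound 4 (0.15 log units; that floor lies within the scatter) and an at least 1.4-fold lower number from compound 2 to compound 4 (0.15 log units; that floor lies within the scatter); each is a floor set by a limit, so a larger true step is possible, but none of the three is established as lying beyond the scatter. The steps among compounds 1, 2 and 3 cannot be read, and the comparison still rests on one number set against a limit shared by the other compounds: the limit of > 64 ug/mL in this assay, at which 3 of the 4 values shown sit.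

Compound 4 exchanges the linking oxygen for a nitrogen and the saturated or sulfonyl-bearing group for a phenyl ring in a single change, so the compounds shown do not separate the contribution of the amide nitrogen from that of the aromatic ring. A benzoyloxy group or a cyclohexanecarboxamido group at the same carbon would divide these two changes, while a free amine there would show whether the benzoyl part is needed at all.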